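Carboxyphenyl in place of pyrazinyl on the biaryl tail

The source may hold more compounds than are shown below. What is called first, only, known or untested is meant among the compounds shown, and "the series" means these compounds.

Measured so far:
compound 1 `CCC(C)(C)Cc1c[nH]c(CCc2ccc(-c3cccc(C)n3)cc2)n1`, 102 nM
compound 2 `CCC(C)(C)Cc1c[nH]c(CCc2ccc(-c3cnccn3)cc2)n1`, 100 nM

Both compounds were tested in a functional assay on HEK293 cells for agonist activity at Bombesin receptor subtype-3 (Homo sapiens), read by luminescence and calcium flux, with a stated time of 10 min; on this read-out higher numbers stand for an effect only at larger amounts of compound and lower numbers for an effect already at smaller amounts. Compound 2 shows the lower of the two numbers, but the gap to compound 1 is within the scatter, as the step of a 1.0-fold lower number from compound 1 to compound 2 (0.01 log units; within the scatter) records, so the two cannot be ordered. The unmeasured compound 3 `CCC(C)(C)Cc1c[nH]c(CCc2ccc(-c3ccccc3C(=O)O)cc2)n1` differs from compound 2 in one place: 2-carboxyphenyl in place of pyrazin-2-yl on an aromatic carbon. Among the compounds with values here, only one measured step bears on this position, the exchange of one six-membered aromatic ring for another, and it left the number unchanged. The new group is larger and carries a carboxylic acid, a change of a different kind from the one measured, so the account carries more uncertainty. He expects a moderate rise in the number for compound 3, a step of a 2.5-fold higher number from compound 2 to compound 3 (0.40 log units; beyond the scatter). His estimate for compound 3 is 250 nM, with a range from 60 nM to 1500 nM.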

Compound 3, half-maximal effective concentration: 101 nM
Beside the measured number, compound 3's estimate is 2.5-fold (0.39 log units) above it, within the range that was stated.
By their numbers in this assay, from the lowest: compounds 2, 3 and 1 (each within the scatter of the next).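

In this assay, the step of a 1.0-fold higher number from compound 2 to compound 3 (0.00 log units; within the scatter) shows that this position accepts a much more different group than the earlier exchange had tested: 2-carboxyphenyl, a ring of carbon only with a carboxylic acid and a hydrogen-bond donor, cannot be told apart from pyrazin-2-yl. The step of a 1.0-fold lower number from compound 1 to compound 3 (0.00 log units; within the scatter) gives the same reading against 6-methylpyridin-2-yl, so on this read-out the three groups cannot be ordered, despite the added heavy atoms of the new group. Nothing available accounts for this result.

From the compounds shown here alone, it remains open what a methyl ester or an aminomethyl group would give in place of the carboxylic acid, so the part played by the acid itself cannot be judged. Going by these compounds, it is also open whether a group larger than 2-carboxyphenyl would give a number within the same scatter.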